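Replacing the 3-cyanophenyl arm of compound 2 with 4-ethoxyphenyl

The source may report more compounds than this note shows. Statements on the series, on what has been measured and on what is new or still open speak of the compounds shown alone.

Compound 2 `COc1cc(N)c(Cl)cc1NC(=O)C1CCN(Cc2cccc(C#N)c2)CC1` stands only at a limit: in a functional assay on the whole organism for antagonist activity, with Mus musculus as the target (a lower number here means that less compound is needed, a higher number that more compound is needed for the effect), compound 2 gives > 4 mg/kg, a limit of the assay. Compound 1 `COc1cc(N)c(Cl)cc1NC(=O)C1CCN(C/C=C/c2ccccc2)CC1` likewise reaches only a limit, > 10 mg/kg in this assay. For the measured compounds named here, the sole measured step, a step that the two limits leave unreadable from compound 1 to compound 2, is unreadable because both values sit at the limits the limit of > 10 mg/kg in this assay, at which 1 of the 2 values shown sits, and (the limit of > 4 mg/kg in this assay, at which 1 of the 2 values shown sits). Compound 3 `CCOc1ccc(CN2CCC(C(=O)Nc3cc(Cl)c(N)cc3OC)CC2)cc1` differs from compound 2 by 4-ethoxyphenyl in place of 3-cyanophenyl on a saturated chain carbon bound to an amine nitrogen in a ring; no readable step bears on this change. The step that the limit leaves unreadable from compound 2 to compound 3 is therefore expected to be none beyond the scatter. Compound 3 is estimated at 10 mg/kg, between 3 mg/kg and 30 mg/kg, most likely again reported as a limit.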

Compound 3, dose for half-maximal effect: 6.3 mg/kg
For compound 3 the middle estimate is 1.6-fold (0.20 log units) above the measured one, and the stated range covers the measured number.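

With 4-ethoxyphenyl at this position, on a saturated chain carbon bound to an amine nitrogen in a ring, the series gains its first true number rather than a limit in this assay: compound 3 gives 6.3 mg/kg. For the compounds shown here, the only readable step is an at least 1.5-fold lower number from compound 1 to compound 3 (0.20 log units; that floor lies within the scatter), so this change shows no gain beyond the scatter. The step from compound 2 to compound 3 cannot be read.

Still open, as far as these compounds go, is whether the ethoxy group matters to this result. A phenyl ring carrying a longer chain such as butoxy, or a carboxylic acid, would help to test this.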